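The source may report more compounds than this note shows. Statements on the series, on what has been measured and on what is new or still open speak of the compounds shown alone.

Compounds measured so far:
compound 1, `Cc1cccc(C(=O)NCN2CCC(c3nccs3)CC2)c1`, with 71%
compound 2, `Cc1cccc(NC(=O)CN2CCC(c3ccccc3)CC2)c1`, with 37%
compound 3, `O=C(CN1CCC(c2cccc[n+]2[O-])CC1)Nc1cccc(Cl)c1Cl`, with 66%

Of the compounds shown here, three have been tested in a functional assay on HEK293 cells for agonist activity at D(4) dopamine receptor (Homo sapiens), read by FLIPR; on this read-out lower numbers stand for smaller maximal responses and higher numbers for larger maximal responses. Compound 1 gives 71%, compound 2 gives 37%, and compound 3 gives 66%. On these three numbers compound 3 stands second highest. Its nearest neighbour is compound 1, whose value lies within the usual scatter of the read-out, so no order can be drawn between the two. Its furthest neighbour is compound 2, whose value lies well below that of compound 3, beyond the scatter.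

The next compound to be measured in this assay is compound 4, `Cc1cccc(C)c1NC(=O)CN1CCC(c2cccc[n+]2[O-])CC1`. It is derived from compound 3 by a single change: 2,6-dimethylphenyl in place of 2,3-dichlorophenyl on an amide-type nitrogen. The amide linkage, the piperidine and the pyridine N-oxide of compound 3 are kept unchanged.

Among the compounds with values here, no pair of measured compounds differs in only one place, so there is no measured step to set against this change. The reference point is compound 3 with 66%, and compound 2 shows that a methyl-bearing phenyl on the amide nitrogen can go with a low value, 37%, though that compound also differs in its piperidine substituent. On this basis a step downward is expected from compound 3 to compound 4, of a size that may not exceed the scatter: a number 11 percentage points lower from compound 3 to compound 4 (beyond the scatter). Compound 4 is estimated to reach 55%, between 35% and 75%.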

Compound 4, largest response reached (reported as efficacy), in percent of the reference or control that the assay uses: 68%
Compound 4: the middle estimate sits 13 percentage points below what was measured, and the stated range covers the measured number.
By their numbers in this assay, from the lowest: compound 2; then compounds 3, 4 and 1 (each within the scatter of the next).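

In this assay the exchange of 2,3-dichlorophenyl for 2,6-dimethylphenyl on an amide-type nitrogen gives a number 2 percentage points higher from compound 3 to compound 4 (within the scatter) and so no change that the read-out can resolve. Within the data shown here, this is the first step between two compounds that differ in one place, and it shows that, on the core shared by this pair, maximal response tolerates this replacement: two chlorine atoms and their ring carbons give way to an all-carbon group of the same heavy-atom count, still with one six-membered aromatic ring, and the number holds within the scatter. No measurement shown here bears on why the two groups match.

As far as these compounds go, what remains open is whether this place accepts groups of a different kind, such as an unsubstituted phenyl, a methoxy-bearing phenyl or a cyclohexyl ring, with the same maximal response. Among these compounds, it is also open whether the match between these two aryl groups would hold if the group on the piperidine were a phenyl or a thiazole instead of the one shared by this pair.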